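The compounds below may be only part of what the source reports. "The series", "measured", "known", "first", "only" and "open" are said of these compounds alone.

Compound 1 `Nc1cccc(-c2cn3nc(CCc4ccccc4)sc3n2)c1` gives 30000 nM in a functional assay on CCRF-CEM cells (Homo sapiens) for inhibition, read by cell counting, with a stated time of 3 days; on this read-out higher numbers stand for weaker inhibition and lower numbers for stronger inhibition. Compound 2 `C=C(Br)C(=O)Nc1cccc(-c2cn3nc(-c4ccc(OC)c(OC)c4)sc3n2)c1` gives 380 nM in this assay. Compound 3 `C=C(Br)C(=O)Nc1cccc(-c2cn3c(-c4ccc(Cl)cc4)csc3n2)c1` gives 2200 nM in this assay.

Among these three, compound 1 has the highest number and is therefore the weakest inhibitor of the set; the gap to compound 3 and the gap to compound 2 both lie beyond the usual scatter. Compound 4 `COc1cccc(Cc2nn3cc(-c4cccc(N)c4)nc3s2)c1` differs from compound 1 in one place: 3-methoxyphenyl in place of benzyl on a saturated chain carbon bound to an aromatic carbon. For the measured compounds named here, no measured pair shows this change on its own, and compounds 2 and 3 each differ from compound 1 in several places at once, so the data give no direct guide to its size. In this assay the expected step is a 1.5-fold lower number from compound 1 to compound 4 (0.18 log units; within the scatter), small and not clearly beyond the scatter. Compound 4 is estimated at 20000 nM in this assay, with a range from 5000 nM to 60000 nM.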

Compound 4, half-maximal inhibitory concentration: 40000 nM
Estimate against measurement, compound 4: 2.0-fold (0.30 log units) below, within the range that was stated.
By their numbers in this assay, from the lowest: compound 2; then compound 3; then compounds 1 and 4 (each within the scatter of the next).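

In this assay, 3-methoxyphenyl in place of benzyl on a saturated chain carbon bound to an aromatic carbon gives a 1.3-fold higher number from compound 1 to compound 4 (0.12 log units; within the scatter), so compound 1 and compound 4 cannot be told apart. At this position, then, the extra oxygen and the hydrogen-bond acceptor that enter with the new group leave no readable mark on the result. Nothing on hand says why this change makes so little difference.

As far as these compounds go, whether a carboxylic acid or a morpholine at this place would shift the number remains open. So does whether this change would read the same in a compound carrying the bromoacrylamide of compound 2.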